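Thiophen-3-yl in place of 2-methylphenyl: working notes

The compounds below may be only part of what the source reports. "The series", "measured", "known", "first", "only" and "open" are said of these compounds alone.

In a functional assay on CAPAN-1 cells (Homo sapiens) for antiproliferative activity, with a stated time of 72 h (on this read-out lower numbers stand for stronger inhibition and higher numbers for weaker inhibition), compound 1 (`Nc1ncnn2c([C@@H]3O[C@H](CO)[C@@H](O)[C@H]3O)cc(-c3ccccc3)c12`) gives 65200 nM and compound 2 (`Cc1ccccc1-c1cc([C@@H]2O[C@H](CO)[C@@H](O)[C@H]2O)n2ncnc(N)c12`) gives 97500 nM. For the measured compounds named here, compound 2 therefore sits within the scatter of compound 1, its only measured neighbour. Going by the values given here, the single measured step, a 1.5-fold higher number from compound 1 to compound 2 (0.17 log units; within the scatter), is methyl in place of hydrogen on an aromatic carbon, and it stays within the scatter.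

Compound 3 (`Nc1ncnn2c([C@@H]3O[C@H](CO)[C@@H](O)[C@H]3O)cc(-c3ccsc3)c12`) carries thiophen-3-yl in place of 2-methylphenyl on an aromatic carbon of the shared core: thiophen-3-yl in place of 2-methylphenyl on an aromatic carbon. Among the compounds with values here, no measured step exchanges the whole aromatic ring, so the methyl step bears on this change only indirectly. With so little evidence, no step beyond the scatter is expected in this assay, though the range stays wide. The expected step is a 1.6-fold lower number from compound 2 to compound 3 (0.21 log units; within the scatter). For compound 3 the estimated value is 60000 nM, with an expected range of 12000 nM to 150000 nM.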

Compound 3, half-maximal inhibitory concentration: 56200 nM
The estimate for compound 3 lay 1.1-fold (0.03 log units) above the measured number; low and high end bracket the measured number.
By their numbers in this assay, from the lowest: compounds 3, 1 and 2 (each within the scatter of the next).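

Replacing the whole aromatic ring on this aromatic carbon of the shared core gives a 1.7-fold lower number from compound 2 to compound 3 (0.24 log units; within the scatter) and a 1.2-fold lower number from compound 1 to compound 3 (0.06 log units; within the scatter) in this assay, so the exchange goes beyond the methyl step without leaving the scatter. Phenyl, 2-methylphenyl and thiophen-3-yl thus give no step beyond the scatter at this position, and neither the six-membered ring of carbon only nor the five-membered ring with sulfur separates these compounds on this read-out. No supporting measurement is available to account for how closely these numbers lie.

The compounds shown leave open whether any group at this position can move the number beyond the scatter, since all three carry a single aromatic ring there. An amine, a carboxylic acid or a longer alkyl chain on this carbon would put that question to a different kind of group.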